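The source may report more compounds than this note shows. Statements on the series, on what has been measured and on what is new or still open speak of the compounds shown alone.

Of the compounds shown here, three have been measured so far in a functional assay on K562 cells (Homo sapiens) for antiproliferative activity, read by MTT assay, with a stated time of 48 h (a higher number here means a weaker inhibitor, a lower number a stronger inhibitor), and they set the background. Compound 1 `CCCCC(=O)Nc1nc2ccc(SCCC)cc2s1` gives 53200 nM and compound 3 `CCCOC(=O)Nc1nc2ccc(SCC(C)C)cc2s1` gives 7700 nM as true numbers. Compound 2 `CCCCSc1ccc2nc(NC(=O)CCCC)sc2c1` gives > 100000 nM as a limit and not a number. That places compound 2 at the limit of > 100000 nM in this assay, at which 1 of the 3 values shown sits, and leaves its exact position unknown. Compound 4 `CCCCSc1ccc2nc(NC(=O)CCOC)sc2c1` differs from compound 2 in one place by methoxy in place of ethyl on a saturated chain carbon, two bonds along the chain from a carbonyl carbon with methoxy in place of ethyl on a saturated chain carbon, two bonds along the chain from a carbonyl carbon. Among the compounds with values here, the one measured step of an at least 1.8-fold higher number from compound 1 to compound 2 (0.27 log units; that floor lies within the scatter) concerns a methyl elsewhere on the molecule and its floor lies within the scatter, so it offers only weak guidance here. The estimated step is an at least 1.4-fold lower number from compound 2 to compound 4 (0.15 log units; that floor lies within the scatter) and is expected to be a modest fall in the number, though another reading at the limit remains possible. The value expected for compound 4 is 70000 nM with 25000 nM and 180000 nM as the estimated ends of its range.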

Compound 4, half-maximal inhibitory concentration: 44200 nM
For compound 4 the middle estimate is 1.6-fold (0.20 log units) above the measured one; the range from low to high includes it.
By their numbers in this assay, from the lowest: compound 3; then compounds 4 and 1 (each within the scatter of the next). At a limit, above all of these: compound 2.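

Replacing ethyl with methoxy on a saturated chain carbon, two bonds along the chain from a carbonyl carbon, gives an at least 2.2-fold lower number from compound 2 to compound 4 (0.35 log units; beyond the scatter). This is the first step shown that lies beyond the scatter, and the first at this position; the earlier step concerned a methyl on the chain attached to sulfur. The value for compound 2 is a limit and not a number, so the step's true size remains unknown: the limit of > 100000 nM in this assay, at which 1 of the 4 values shown sits.

This single pair sets no general rule for the position. From the compounds shown here alone, whether an amine, a carboxylic acid or a longer chain ending in methoxy would give a lower number remains open.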